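The source may hold more compounds than are shown below. What is called first, only, known or untested is meant among the compounds shown, and "the series" means these compounds.

Compound 1 `C=CS(=O)(=O)N1CCN(c2ncnc3sc(-c4ccc(OC)cc4)cc23)CC1` gives 29900 nM in a functional assay on MDA-MB-231 cells (Homo sapiens) for antiproliferative activity, read by MTT assay, with a stated time of 48 h; a higher number here means a weaker inhibitor, a lower number a stronger inhibitor. Compound 2 `C=CS(=O)(=O)N1CCN(c2ncnc3sc(-c4ccc(C#N)cc4)cc23)CC1` gives 8050 nM, and compound 3 `C=CS(=O)(=O)N1CCN(c2ncnc3sc(-c4ccc(N5CCN(C)CC5)cc4)cc23)CC1` gives 7550 nM. Compound 2 thus holds the second highest of the three numbers: its separation from compound 3 lies within the scatter, while the change a 3.7-fold lower number from compound 1 to compound 2 (0.57 log units; beyond the scatter) is a modest step beyond it, as is a 4.0-fold lower number from compound 1 to compound 3 (0.60 log units; beyond the scatter).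

Compound 4 `C=CS(=O)(=O)N1CCN(c2nc(OC[C@H]3CCCN3C)nc3sc(-c4ccc(C#N)cc4)cc23)CC1` differs from compound 2 by (1-methylpyrrolidin-2-yl)methoxy in place of hydrogen on an aromatic carbon on the shared core. Going by the values given here, none of the measured steps touches this position; all of them change the group on the aromatic carbon of the pendant ring, so no step bears directly on the change from compound 2 to compound 4.

With that gap in the evidence, compound 4 is estimated at 4000 nM (range 1000 nM to 16000 nM), an expected step of a 2.0-fold lower number from compound 2 to compound 4 (0.30 log units; within the scatter).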

Compound 4, half-maximal inhibitory concentration: 3010 nM
Compound 4: the middle estimate sits 1.3-fold (0.12 log units) above what was measured; measured number inside the range.
By their numbers in this assay, from the lowest: compound 4; then compounds 3 and 2 (each within the scatter of the next); then compound 1.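

Going by these compounds alone, at the carbon between two ring nitrogen atoms, which none of the earlier steps touched, the shared core accepts a substituent: in this assay (1-methylpyrrolidin-2-yl)methoxy in place of hydrogen gives a 2.7-fold lower number from compound 2 to compound 4 (0.43 log units; beyond the scatter) and so moves the number beyond the scatter. No evidence is available to account for this step.

The compounds shown leave open whether a plain methoxy, a 2-(dimethylamino)ethoxy chain or a morpholine at this carbon would give a similar step. They also leave open whether the defined stereocentre matters, and whether the step carries over when 4-methylpiperazin-1-yl replaces the cyano group.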